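Hydroxy to methoxy in a two-compound series

The compounds below may be only part of what the source reports. "The series", "measured", "known", "first", "only" and "open" are said of these compounds alone.

Measured so far in a functional assay on SK-MEL-5 cells (Homo sapiens) for antiproliferative activity, read by sulforhodamine B assay, with a stated time of 48 h (a lower number here means a stronger inhibitor, a higher number a weaker inhibitor), are these compounds
- compound 1 `O=C(NCCCNc1cc(-c2cn(-c3ccccc3)nc2-c2cccc(O)c2)ccn1)Nc1ccc(F)cc1` gives 1640 nM
- compound 2 `O=C(NCCCNc1cc(-c2cn(-c3ccccc3)nc2-c2cccc(O)c2)ccn1)Nc1cccc(C(F)(F)F)c1` gives 3250 nM

Going by the values given here, compound 1 and compound 2 supply the only two values in this assay and sit within the scatter of each other, so neither can be ranked over the other. Compound 3 `COc1cccc(-c2nn(-c3ccccc3)cc2-c2ccnc(NCCCNC(=O)Nc3ccc(F)cc3)c2)c1` departs from compound 1 by a single change (methyl in place of hydrogen on an oxygen on an aromatic ring), methyl in place of hydrogen on an oxygen on an aromatic ring, which turns 3-hydroxyphenyl to 3-methoxyphenyl. Among the compounds with values here, the one measured step (a 2.0-fold higher number from compound 1 to compound 2 (0.30 log units; within the scatter)) swaps 4-fluorophenyl for 3-(trifluoromethyl)phenyl on an amide-type nitrogen, so it lies elsewhere in the molecule and says nothing direct about this oxygen. Within the data shown here, no measured pair tests the hydroxy to methoxy change. That step is therefore only a loose guide to how far numbers move here, and it stayed within the scatter. No shift beyond the scatter is expected, and the data argue for no direction. The estimated step (a 1.3-fold higher number from compound 1 to compound 3 (0.13 log units; within the scatter)) is accordingly small. In this assay the estimate for compound 3 is 2200 nM (expected range 800 nM to 6500 nM).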

Compound 3, half-maximal inhibitory concentration: 5640 nM
Compound 3: middle estimate off by 2.6-fold (0.41 log units), on the low side; the measured number falls inside the stated range.
By their numbers in this assay, from the lowest: compounds 1, 2 and 3 (each within the scatter of the next, the first and the last beyond it).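

In this assay, going by these compounds alone, the change from hydroxy to methoxy gives the first step beyond the scatter (a 3.4-fold higher number from compound 1 to compound 3 (0.54 log units; beyond the scatter)), although it is only a modest one, and the free hydroxy form holds the lower number. The earlier pair varied only the aryl group on the amide-type nitrogen and stayed within the scatter, so it could not show that the number responds to anything; this oxygen on an aromatic ring is the one place shown where a single methyl, adding just 1 heavy atom, moves the number beyond the scatter. No measurement presented here speaks to why the methyl has this effect, so the step stands as an observation without an explanation.

What the compounds shown leave open is whether the step tracks the methyl itself, since an ethoxy group, an amino group or a carboxylic acid in place of the hydroxy would each test this oxygen differently. As far as these compounds go, it is also open whether the same change would move the number as far when the 3-(trifluoromethyl)phenyl group of compound 2 stands on the amide-type nitrogen.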